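Compound 4: A Longer Group on the Hydroxy Carbon

The compounds below may be only part of what the source reports. "The series", "measured", "known", "first", "only" and "open" are said of these compounds alone.

Measured in a functional assay on a cell-free system (plasma, Homo sapiens), with a stated time of 3 min; a lower number here means a stronger inhibitor, a higher number a weaker inhibitor:
- Compound 1 `CC(C)(C)[C@@H](O)C(=O)N1C[C@@H]2C[C@@H]2[C@H]1C(=O)NCc1cc(Cl)ccc1-n1cnnn1` gives 570 nM
- Compound 2 `CC(C)(C)C[C@@H](O)C(=O)N1N=CC[C@H]1C(=O)NCc1cc(Cl)ccc1-n1cnnn1` gives 590 nM
- Compound 3 `CC(C)(C)[C@@H](O)C(=O)N1C[C@H]2C[C@H]2[C@H]1C(=O)NCc1cc(Cl)ccc1-n1cnnn1` gives 1200 nM

Compound 1 has the lowest of the three numbers, but it lies within the scatter of compound 2, so the two cannot be ranked. Compound 3 sits higher. Going by the values given here, the only measured step is modest: a 2.1-fold higher number from compound 1 to compound 3 (0.32 log units; beyond the scatter). It reflects (the fact that compounds 1 and 3 differ only in the configuration as drawn), and the tert-butyl group is the same on both sides of it. It therefore offers little guidance for the next change.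

Compound 4 `CC(C)(C)OC[C@@H](O)C(=O)N1C[C@@H]2C[C@@H]2[C@H]1C(=O)NCc1cc(Cl)ccc1-n1cnnn1` carries (tert-butoxy)methyl in place of tert-butyl on a saturated chain carbon bound to a carbonyl carbon and an oxygen on a saturated carbon. Among the compounds with values here, no measured step tests this change, so no step beyond the scatter is expected in this assay, though the uncertainty is wide. The expected step is a 1.1-fold higher number from compound 1 to compound 4 (0.02 log units; within the scatter). The estimated value for compound 4 is 600 nM, with an expected range of 200 nM to 1800 nM.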

Compound 4, half-maximal inhibitory concentration: 570 nM
Compound 4: middle estimate off by 1.1-fold (0.02 log units), on the high side; the measured number falls inside the stated range.
By their numbers in this assay, from the lowest: compounds 1, 4 and 2 (each within the scatter of the next); then compound 3.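

With (tert-butoxy)methyl in place of tert-butyl, this assay shows no change at the digits printed from compound 1 to compound 4 (within the scatter) at this position on the core of compound 1. The earlier compounds shown here showed only a change of configuration with tert-butyl kept the same, whereas this result shows that a longer group carrying an oxygen and a hydrogen-bond acceptor can stand on this carbon with no step beyond the scatter. No information given here bears on why this replacement leaves the number within the scatter.

The compounds shown leave open whether an amine, a carboxylic acid or a longer chain on this carbon would also stay within the scatter of compound 1. They also leave open whether (tert-butoxy)methyl would give a similar step on the core of compound 3.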